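A second chloro group on two related purine-like cores

A few compounds are considered here, and "the series" means these few. Any claim that something is new, unique, unknown or untested is made for them only; others in the source may bear on it.

Compound 1 `ClCc1ccc(Cn2cnc3c(Cl)ncnc32)cc1` and compound 2 `ClCc1cccc(Cn2cnc3ncnc(Cl)c32)c1` share the same atoms joined differently; the difference between the two cores is not broken down here. In a functional assay on U-251 cells (Homo sapiens) for cytotoxicity, read by sulforhodamine B assay, with a stated time of 48 h (on this read-out lower numbers stand for stronger inhibition of growth and higher numbers for weaker inhibition of growth), compound 1 gives 1250 nM, and compound 2 gives 1940 nM. Compound 3 `ClCc1ccc(Cn2cnc3c(Cl)nc(Cl)nc32)cc1` carries the change chloro in place of hydrogen on an aromatic carbon relative to compound 1, and in this assay compound 3 gives 2040 nM, so that the step of a 1.6-fold higher number from compound 1 to compound 3 (0.21 log units; within the scatter) stays within the scatter. Compound 4 `ClCc1cccc(Cn2cnc3nc(Cl)nc(Cl)c32)c1`, not yet measured, carries the same change relative to compound 2, namely (chloro in place of hydrogen on an aromatic carbon). Because the step of a 1.6-fold higher number from compound 1 to compound 3 (0.21 log units; within the scatter) was small, the step from compound 2 to compound 4 is expected to be of similar size, a 1.5-fold higher number from compound 2 to compound 4 (0.19 log units; within the scatter). Compound 4 is therefore estimated at 3000 nM, with a likely range from 1500 nM to 6500 nM.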

Compound 4, concentration for 50% growth inhibition: 1380 nM
Compound 4: the middle estimate sits 2.2-fold (0.34 log units) above what was measured; the whole stated range lies above it.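

In this assay, chloro in place of hydrogen on an aromatic carbon gives a 1.4-fold lower number from compound 2 to compound 4 (0.15 log units; within the scatter). Set beside the earlier step, this one does not differ from it by more than repeated measurement allows: the same change on two cores in this assay, a 1.6-fold higher number (0.21 log units; within the scatter) from compound 1 to compound 3 and a 1.4-fold lower number (0.15 log units; within the scatter) from compound 2 to compound 4, 2.3-fold (0.36 log units) apart, within the scatter of two such steps. On these two cores, then, the change leaves the number within the scatter and the core gives no sign of altering that outcome, but two pairs do not show that the change would behave alike on any other core.

As far as these compounds go, what an amine, a methoxy group or a longer chain would do in place of this chloro group stays open. So does the outcome of the same change on any further core.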